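Chloropyridine amide on the biaryl diethoxy core

A few compounds are considered here, and "the series" means these few. Any claim that something is new, unique, unknown or untested is made for them only; others in the source may bear on it.

Compound 3 `CCOc1cc(CN2CCC(NC(=O)c3cncc(C)c3)CC2)cc(OCC)c1-c1ccc(F)cc1` is the biaryl member of the set carrying a 5-methylpyridin-3-yl group on the carbonyl carbon. Among the compounds with values here, in a physicochemical assay for solubility, in phosphate buffer, at pH 6.5 (a higher number here means a more soluble compound, a lower number a less soluble compound), compound 3 gives 94 ug/mL, the lowest of the three numbers so far. Compound 1 `CCOc1cc(CN2CCC(NC(=O)c3ccc(N)nc3)CC2)cc(OCC)c1-c1ccc(F)cc1` gives 123 ug/mL in this assay, and the step of a 1.3-fold lower number from compound 1 to compound 3 (0.12 log units; within the scatter) stays within the scatter. Compound 2 `CCOc1cc(CN2CCC(NC(=O)c3cncc(C)c3)CC2)cc(OCC)c1Cl` gives 216 ug/mL in this assay; the step of a 2.3-fold lower number from compound 2 to compound 3 (0.36 log units; beyond the scatter) is modest but beyond the scatter.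

Compound 4 `CCOc1cc(CN2CCC(NC(=O)c3ccc(Cl)nc3)CC2)cc(OCC)c1-c1ccc(F)cc1` differs from compound 3 in one place: 6-chloropyridin-3-yl in place of 5-methylpyridin-3-yl on a carbonyl carbon. Within the data shown here, the only measured step at this position, a 1.3-fold lower number from compound 1 to compound 3 (0.12 log units; within the scatter), was within the scatter, so one exchange of the group on the carbonyl carbon has so far moved this assay little. Among the measured compounds shown here, no measured step puts chloro in place of methyl on this group, so the direction is open. The expected step is small, leaning slightly lower, a 1.3-fold lower number from compound 3 to compound 4 (0.10 log units; within the scatter). Compound 4 is expected to give 75 ug/mL in this assay, within a range from 35 ug/mL to 160 ug/mL.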

Compound 4, solubility: 76 ug/mL
Beside the measured number, compound 4's estimate is 1.0-fold (0.01 log units) below it; the measured number falls inside the stated range.
By their numbers in this assay, from the lowest: compounds 4, 3, 1 and 2 (each within the scatter of the next, the first and the last beyond it).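

The step of a 1.2-fold lower number from compound 3 to compound 4 (0.09 log units; within the scatter) adds chloro to the substituents tried on the pyridine at this position, and the step of a 1.6-fold lower number from compound 1 to compound 4 (0.21 log units; within the scatter) sets it directly against amino, with neither reaching beyond the scatter. Compounds 1, 3 and 4 therefore all stand within the scatter of one another in this assay, so amino, methyl and chloro on the pyridinyl group on the carbonyl carbon give no readable separation while the 4-fluorophenyl group is held constant. No measurement at hand offers an account of this lack of separation.

It remains open whether the same holds with chloro in place of 4-fluorophenyl on the shared core, where only the 5-methylpyridin-3-yl amide, compound 2, is shown. On these data alone, it is also open whether a carboxylic acid, a morpholine or a longer alkyl chain on the pyridine would move this assay beyond the scatter.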